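Chain ester swap: from cyclohexylcarbonyl amide to methoxymethyl ester

The compounds below may be only part of what the source reports. "The series", "measured", "known", "first", "only" and "open" are said of these compounds alone.

Compound 1 `Cc1ncsc1-c1ccc(CNC(=O)[C@@H]2C[C@@H](O)CN2C(=O)[C@@H](NC(=O)CCCCCOC(=O)C2CCCCC2)C(C)(C)C)cc1`: 1.1
Compound 2 `Cc1ncsc1-c1ccc(CNC(=O)[C@@H]2C[C@@H](O)CN2C(=O)[C@@H](NC(=O)CCCCCNC(=O)C2CCCCC2)C(C)(C)C)cc1`: 1.4

In a physicochemical assay for lipophilicity, read by LC-MS, using the shake flask method, in phosphate buffer, with a stated time of 50 min, at pH 7.4 (a lower number here means a more polar compound, a higher number a more lipophilic compound), compound 2 gives the higher of the two numbers, with compound 1 nearest at 1.1, a difference within the scatter. Compound 3 `COCC(=O)OCCCCCC(=O)N[C@H](C(=O)N1C[C@H](O)C[C@H]1C(=O)NCc1ccc(-c2scnc2C)cc1)C(C)(C)C` differs from compound 2 by ((methoxymethyl)carbonyl)oxy in place of (cyclohexylcarbonyl)amino on a saturated chain carbon, five bonds along the chain from a carbonyl carbon. Going by the values given here, the only measured step that touches this part of the chain, a number 0.30 log units higher from compound 1 to compound 2 (within the scatter), exchanged ester for amide while keeping the ring and stayed within the scatter; no measured step covers the loss of the ring. Compound 3 is nevertheless expected to read lower than compound 2, by a number 1.90 log units lower from compound 2 to compound 3 (beyond the scatter), and is estimated at -0.5, within -1.4 to 0.4.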

Compound 3, distribution coefficient: 1.7
Beside the measured number, compound 3's estimate is 2.20 log units below it; the whole stated range lies below it.
By their numbers in this assay, from the lowest: compounds 1, 2 and 3 (each within the scatter of the next, the first and the last beyond it).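

In this assay the exchange of (cyclohexylcarbonyl)amino for ((methoxymethyl)carbonyl)oxy on this saturated chain carbon gives a number 0.30 log units higher from compound 2 to compound 3 (within the scatter) and so shows no drop on losing the ring. Going by these compounds alone, with the ester kept, methoxymethyl in place of cyclohexyl on the carbonyl carbon gives a number 0.60 log units higher from compound 1 to compound 3 (beyond the scatter) and is the first step here beyond the scatter, pointing upward. No measurement at hand accounts for this direction.

The compounds shown leave open how the methoxymethyl amide would read in this assay and whether an amine or a carboxylic acid on this chain would follow the same direction.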